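The source may report more compounds than this note shows. Statements on the series, on what has been measured and on what is new or still open speak of the compounds shown alone.

For the measured compounds named here, in a toxicity assay on NIH3T3 cells (Mus musculus) for cytotoxicity, read by resazurin assay (a higher number here means that more compound is needed for the effect, a lower number that less compound is needed), no compound in this short series has yet given an exact number. Compound 1 `CC(=O)c1ccc(NCc2cncn2Cc2ccc(-c3ccccc3)cc2)cc1-c1ccccc1` gives > 10000 nM, which is a limit of the assay and not a number. Compound 2 `Nc1cc(-c2ccccc2)ccc1Cn1cncc1CNc1ccc(Cl)c(-c2ccccc2)c1` gives > 1000 nM, also a limit. Compound 3 `COc1ccc(NCc2cncn2Cc2ccc(-c3ccccc3)cc2N)cc1-c1ccccc1` gives > 1000 nM, again a limit. Compound 3 therefore has no exact place on the scale, and the values gather at the limit of > 1000 nM in this assay, at which 2 of the 3 values shown sit, and at the limit of > 10000 nM in this assay, at which 1 of the 3 values shown sits.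

Compound 4 `CNC(=O)c1ccc(NCc2cncn2Cc2ccc(-c3ccccc3)cc2N)cc1-c1ccccc1` carries methylcarbamoyl in place of methoxy on an aromatic carbon, ortho to a phenyl group and para to a large group (methylcarbamoyl in place of methoxy on an aromatic carbon). Going by the values given here, the one measured step that bears on this carbon is a step that the two limits leave unreadable from compound 2 to compound 3, so it offers no size to carry over. Nothing measured points to a move in either direction in this assay, and compound 4 is expected to stay at the high-concentration end, perhaps as another limit. The expected step, a step that the limit leaves unreadable from compound 3 to compound 4, is only a rough estimate. For compound 4 the estimated half-maximal effective concentration is 5000 nM, with an expected range from 1500 nM to 20000 nM.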

Compound 4, half-maximal effective concentration: > 1000 nM
Compound 4: a limit, no number; the forecaster's own chance of this, stated with the estimate: 80%; the middle value does not contradict the limit.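

In this assay compound 4 gives > 1000 nM, a limit and not a number. For the compounds shown here, with only limits for compound 2, compound 3 and compound 4, no step between them can be read. From the compounds shown here alone, whether chloro, methoxy or methylcarbamoyl on this aromatic carbon changes the concentration needed for cytotoxicity stays open.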